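Swapping the aryl group on a shared core

This account rests on a few compounds, and the source may have more. Where it says the series, first, only, none or still open, it means among the compounds named here.

Compound 2 `COc1ccc(C(C2=C(O)C(=O)c3ccccc3C2=O)c2c[nH]c3ccccc23)cc1Br` is one of two compounds tested in a toxicity assay (Homo sapiens) for cytotoxicity, read by MTT assay, with a stated time of 48 h (a higher number here means a weaker inhibitor, a lower number a stronger inhibitor), where compound 2 gives 25200 nM. Compound 1 `COc1cc(C(C2=C(O)C(=O)c3ccccc3C2=O)c2c[nH]c3ccc(Br)cc23)cc(OC)c1OC` gives 36300 nM in this assay, a number within the usual scatter of that of compound 2, so the two cannot be told apart. Compound 3 `O=C1C(O)=C(C(c2ccc(Cl)cc2)c2c[nH]c3ccccc23)C(=O)c2ccccc21` has not been measured. Its change from compound 2 is 4-chlorophenyl in place of 3-bromo-4-methoxyphenyl on a saturated chain carbon bound to an aromatic carbon and a double-bonded ring carbon. Going by the values given here, no measured pair shows the effect of such a swap, so the expected step from compound 2 to compound 3 is a 1.2-fold higher number from compound 2 to compound 3 (0.08 log units; within the scatter), within the scatter in either direction. Compound 3 is therefore estimated at 30000 nM, with a range from 10000 nM to 90000 nM.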

Compound 3, half-maximal inhibitory concentration: 102000 nM
Compound 3: the middle estimate sits 3.4-fold (0.53 log units) below what was measured; the measured number lies above the stated range.
By their numbers in this assay, from the lowest: compounds 2 and 1 (each within the scatter of the next); then compound 3.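

In this assay, the group on this saturated chain carbon turns out to matter: 4-chlorophenyl in place of 3-bromo-4-methoxyphenyl gives a 4.0-fold higher number from compound 2 to compound 3 (0.61 log units; beyond the scatter), a step beyond the scatter towards a weaker inhibitor. Going by these compounds alone, no earlier measured pair showed the effect of any swap at this place. Nothing available offers an explanation for this step.

As far as these compounds go, whether the methoxy group or the halogen carries the step stays open, and a plain 4-methoxyphenyl or 3-bromophenyl group would separate the two. From the compounds shown here alone, how an amine or a carboxylic acid at this place would read is also open.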